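The source may hold more compounds than are shown below. What is called first, only, known or untested is meant among the compounds shown, and "the series" means these compounds.

Compound 2 `Cc1nc(Nc2ccccc2)nc(N[C@@H]2C[C@H](CO)[C@@H](O)[C@H]2O)c1-c1nc2cnccc2s1` sits in an ADME assay on cells (Homo sapiens) for cytotoxicity, read by polymerase chain reaction, with a stated time of 3 days (a higher number here means that more compound is tolerated, a lower number that less compound is tolerated), at 25000 nM. The nearest point of comparison, compound 1 `Cc1nc(N(C)C)nc(N[C@@H]2C[C@H](CO)[C@@H](O)[C@H]2O)c1-c1nc2cnccc2s1`, gives 25000 nM in this assay, and the step of no change at the digits printed from compound 1 to compound 2 (within the scatter), anilino in place of dimethylamino on an aromatic carbon, leaves the read-out where it was. Compound 2 therefore stands level with compound 1 at the digits shown, with no other measured neighbour.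

Compound 3 `COc1cc(OC)cc([C@@H](C)Nc2nc(C)c(-c3nc4cnccc4s3)c(N[C@@H]3C[C@H](CO)[C@@H](O)[C@H]3O)n2)c1` is the next member and has not yet been measured. It differs from compound 2 by 1-(3,5-dimethoxyphenyl)ethyl in place of phenyl on a nitrogen on an aromatic ring.

Going by the values given here, only the step from compound 1 to compound 2 bears on this, and only loosely: it also exchanged the group on that part of the shared core and showed no change beyond the scatter. The change to compound 3 is a bigger rearrangement of structure, but nothing measured points to a direction. The expected step of no change at the digits printed from compound 2 to compound 3 (within the scatter) is accordingly none beyond the scatter. Compound 3 is estimated at 25000 nM in this assay, with a range from 10000 nM to 50000 nM.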

Compound 3, half-maximal cytotoxic concentration: 25000 nM
The estimate for compound 3 equals the measured number at the digits printed; the measured number falls inside the stated range.
By their numbers in this assay, from the lowest: compounds 1, 2 and 3 (each within the scatter of the next).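

In this assay, the exchange at the nitrogen on an aromatic ring gives no change at the digits printed from compound 2 to compound 3 (within the scatter), so this place in the series takes 1-(3,5-dimethoxyphenyl)ethyl with no read-out shift beyond the scatter. The earlier step concerned only anilino against dimethylamino; this one tests a far larger substituent, with 12 heavy atoms entering against 6 for phenyl, together with 2 hydrogen-bond acceptors and 1 defined stereocentre, none of which phenyl carries. Nothing measured explains the flat result, and no separate measurement bears on the individual features of the entering group.

Still open, on these data alone, is whether a substituent of a different kind on this nitrogen, such as a chain ending in a carboxylic acid or a primary amine, would shift the number in this assay. The compounds shown also leave open what the opposite configuration at the defined stereocentre would give, and whether the unsubstituted 1-phenylethyl group would read the same as 1-(3,5-dimethoxyphenyl)ethyl.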